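Extending the chain from compound 3 to compound 4

The source may hold more compounds than are shown below. What is called first, only, known or untested is meant among the compounds shown, and "the series" means these compounds.

Of the compounds shown here, three sharing a core have been measured in a functional assay on HEL cells (Homo sapiens) for inhibition; a lower number here means a stronger inhibitor, a higher number a weaker inhibitor. Compound 1 `CC(C)c1cc(-c2n[nH]c(=O)n2-c2cccc(C(=O)NCCCCCC(=O)NO)c2)c(O)cc1O` gives 4600 nM, compound 2 `CC(C)c1cc(-c2n[nH]c(=O)n2-c2cccc(NC(=O)CCCCCC(=O)NO)c2)c(O)cc1O` gives 1600 nM, and compound 3 `CC(C)c1cc(-c2n[nH]c(=O)n2-c2cccc(C(=O)NCCCC(=O)NO)c2)c(O)cc1O` gives 4600 nM. Compound 3 therefore stands level with compound 1, the pair sharing the highest number of the three, while the value of compound 2 lies lower, beyond the scatter.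

The next structure is compound 4 `CC(C)c1cc(-c2n[nH]c(=O)n2-c2cccc(C(=O)NCCCCCCC(=O)NO)c2)c(O)cc1O`. The change is 3-(hydroxycarbamoyl)propyl in place of hydroxycarbamoyl on a saturated chain carbon, three bonds along the chain from an amide-type nitrogen.

Among the compounds with values here, one measured step bears on this, at the same place: no change at the digits printed from compound 1 to compound 3 (within the scatter), with hydroxycarbamoyl in place of 2-(hydroxycarbamoyl)ethyl. Within the data shown here, compound 2 is joined to compound 3 by no single-place step, so it offers only its value. The group entering compound 4 is longer than either group measured at this place, so the extension goes past the measured range and the range of the estimate stays wide.

Among the measured compounds shown here, with only that flat step as a guide, no change beyond the scatter is expected in this assay. The expected step is a 1.2-fold lower number from compound 3 to compound 4 (0.08 log units; within the scatter). For compound 4 the estimated value is 3800 nM, with an expected range of 1600 nM to 9000 nM.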

Compound 4, half-maximal inhibitory concentration: 4600 nM
For compound 4 the middle estimate is 1.2-fold (0.08 log units) below the measured one; the measured number falls inside the stated range.
By their numbers in this assay, from the lowest: compound 2; then compounds 1, 3 and 4 (each within the scatter of the next).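

In this assay, replacing hydroxycarbamoyl with 3-(hydroxycarbamoyl)propyl at this place gives no change at the digits printed from compound 3 to compound 4 (within the scatter), so the flat reading now covers a larger change than the one measured before. Replacing hydroxycarbamoyl with (hydroxycarbamoyl)methyl on a saturated chain carbon, five bonds along the chain from an amide-type nitrogen, gives no change at the digits printed from compound 1 to compound 4 (within the scatter), and compound 1, compound 3 and compound 4 therefore show no dependence on chain length in this amide series, with none of the three going against that reading. Nothing available here explains why the number stays flat across these chains.

Within the data shown here, compound 2 gives 1600 nM in this assay and is joined to compound 1, compound 3 and compound 4 by no single-place step, so what separates it from them remains unread. Also open, as far as these compounds go, is whether a carboxylic acid in place of hydroxycarbamoyl, or a still longer chain than 3-(hydroxycarbamoyl)propyl, would shift the number in this assay beyond the scatter.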